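From pyridin-3-yl to 4-methyl-1,3-thiazol-2-yl on the amide

The compounds below may be only part of what the source reports. "The series", "measured", "known", "first", "only" and "open" are said of these compounds alone.

Measured in a physicochemical assay for solubility, read by nephelometry, measured as kinetic solubility, at pH 2.0; a lower number here means a less soluble compound, a higher number a more soluble compound:
- compound 1 `CC(C)(C)c1cc(C(=O)Nc2cccc(CN)c2)n(Cc2ccccc2)n1`: > 100 ug/mL (a limit)
- compound 2 `CC(C)(C)c1cc(C(=O)Nc2ccccn2)n(Cc2ccccc2)n1`: 25 ug/mL
- compound 3 `CC(C)(C)c1cc(C(=O)Nc2cccnc2)n(Cc2ccccc2)n1`: > 100 ug/mL (a limit)

Compound 3 has no number, only a limit; it stands at the limit of > 100 ug/mL in this assay, at which 2 of the 3 values shown sit. Compound 4 `Cc1csc(NC(=O)c2cc(C(C)(C)C)nn2Cc2ccccc2)n1` carries 4-methyl-1,3-thiazol-2-yl in place of pyridin-3-yl on an amide-type nitrogen.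

The nearest measured change is an at least 4.0-fold higher number from compound 2 to compound 3 (0.60 log units; beyond the scatter). The step of an at least 4.0-fold lower number from compound 1 to compound 2 (0.60 log units; beyond the scatter) is likewise beyond the scatter, so swapping this group alone can move the read-out. The step that the two limits leave unreadable from compound 1 to compound 3 gives no size. Going by the values given here, compound 2 at 25 ug/mL holds the only true number, and the expectation leans toward it. The expected change, to a lower number, is an at least 5.0-fold lower number from compound 3 to compound 4 (0.69 log units; beyond the scatter). Compound 4 is estimated at 20 ug/mL, with an expected range of 6 ug/mL to 70 ug/mL.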

Compound 4, solubility: < 1.6 ug/mL
Compound 4 ended at the assay's limit; the forecaster's own chance of this, stated with the estimate: 15%; middle value at least 12-fold (1.09 log units) from the limit.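

In this assay compound 4 gives < 1.6 ug/mL, which is a limit and not a number. Going by these compounds alone, this position can carry much larger steps than the earlier compounds showed: an at least 62-fold lower number from compound 3 to compound 4 (1.79 log units; beyond the scatter), an at least 15-fold lower number from compound 2 to compound 4 (1.19 log units; beyond the scatter) and an at least 62-fold lower number from compound 1 to compound 4 (1.79 log units; beyond the scatter). The pyridin-3-yl and 4-methyl-1,3-thiazol-2-yl groups count the same heavy atoms and no net charge, so those two counts do not fix the read-out here.

The compounds shown do not separate the five-membered ring from its methyl; a plain 1,3-thiazol-2-yl would. On these data alone, how far compound 4 lies past its limit also stays open.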